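Swapping the Aryl Group: From Compound 2 to Compound 3

This account rests on a few compounds, and the source may have more. Where it says the series, first, only, none or still open, it means among the compounds named here.

Compound 1 `COC(=O)c1cc(NC2=NC(=O)/C(=C/c3ccc(C)cc3)S2)ccc1O` — 410 nM
Compound 2 `COC(=O)c1cc(NC2=NC(=O)/C(=C/c3ccccc3O)S2)ccc1O` — 500 nM

Of the compounds shown here, two have so far been measured in a functional assay on MCF7 cells (Homo sapiens) for antiproliferative activity, read by sulforhodamine B assay, with a stated time of 48 h; on this read-out lower numbers stand for stronger inhibition and higher numbers for weaker inhibition. Compound 1 gives 410 nM in this assay, and compound 2 gives 500 nM. Of the two numbers, that of compound 2 is the higher, yet the step of a 1.2-fold higher number from compound 1 to compound 2 (0.09 log units; within the scatter) lies within the scatter, so the two compounds are not distinguished by this read-out.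

Compound 3 `COC(=O)c1cc(NC2=NC(=O)/C(=C/c3ccc(Br)cc3)S2)ccc1O` has not yet been measured. It differs from compound 2 in one place: 4-bromophenyl in place of 2-hydroxyphenyl on a double-bonded chain carbon bound to a double-bonded ring carbon. Within the data shown here, only one measured step touches the same position, namely a 1.2-fold higher number from compound 1 to compound 2 (0.09 log units; within the scatter), and that exchange did not move the number beyond the scatter. With nothing else to go on, no shift beyond the scatter is expected in this assay for compound 3 either, and the expected step is a 1.2-fold lower number from compound 2 to compound 3 (0.08 log units; within the scatter). Compound 3 is therefore estimated at 420 nM, with a range from 150 nM to 1200 nM.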

Compound 3, half-maximal inhibitory concentration: 70 nM
The estimate for compound 3 lay 6.0-fold (0.78 log units) above the measured number, outside the stated range (below it).
By their numbers in this assay, from the lowest: compound 3; then compounds 1 and 2 (each within the scatter of the next).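

Compounds 1 and 2 had suggested that this position on a double-bonded chain carbon bound to a double-bonded ring carbon made little difference, but compound 3 shows that the aryl group there can move the number in this assay. The exchange of 2-hydroxyphenyl for 4-bromophenyl gives a 7.1-fold lower number from compound 2 to compound 3 (0.85 log units; beyond the scatter), so this position responds to at least one aryl group. The closest comparison is with 4-methylphenyl, where bromo in place of methyl on an aromatic carbon gives a 5.9-fold lower number from compound 1 to compound 3 (0.77 log units; beyond the scatter); compound 1 also has no hydroxyl on this aryl group and yet stays within the scatter of compound 2, so the absence of that hydroxyl does not by itself go with the lower number. Nothing in the data shown accounts for the separation of bromo from methyl.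

The compounds shown leave open whether the lower number belongs to bromo alone or would also appear with 4-chlorophenyl, 4-fluorophenyl or 4-methoxyphenyl at this position. They also leave open whether the gain would persist if the methyl ester of the shared core gave way to a carboxylic acid or an amide.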